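Saturating the chain in a second urea series

A few compounds are considered here, and "the series" means these few. Any claim that something is new, unique, unknown or untested is made for them only; others in the source may bear on it.

Compound 1, `CCCCCCCC/C=C\CCCCCCCCNC(=O)Nc1c(OC)cc(OC)cc1OC`: 320 nM
Compound 2, `CCCCCCCCCCCCCCCCCCNC(=O)Nc1c(OC)cc(OC)cc1OC`: 900 nM
Compound 3, `CCCCCCCC/C=C\CCCCCCCCNC(=O)Nc1c(C)cccc1Cl`: 180 nM

Three ureas with long hydrocarbon chains have been measured in an assay on microsomes from intestinal mucosa for inhibition of acyl-CoA:cholesterol acyltransferase (Oryctolagus cuniculus); a lower number here means a stronger inhibitor, a higher number a weaker inhibitor. Compound 1 and compound 2 share one core; compound 3 carries another, and the difference between the two cores is not broken down here. The numbers for compound 1 and compound 3 lie within the usual scatter of each other, whereas compound 3 gives a lower number than compound 2, a gap that lies beyond the scatter.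

Within the first core, one change has already been tested: decyl in place of dec-1-en-1-yl on a saturated chain carbon, eight bonds along the chain from an amide-type nitrogen. It gave a 2.8-fold higher number from compound 1 to compound 2 (0.45 log units; beyond the scatter).

Compound 4, `CCCCCCCCCCCCCCCCCCNC(=O)Nc1c(C)cccc1Cl`, is not yet measured. It applies the same change to compound 3: decyl in place of dec-1-en-1-yl on a saturated chain carbon, eight bonds along the chain from an amide-type nitrogen. Because the same change gave a 2.8-fold higher number from compound 1 to compound 2 (0.45 log units; beyond the scatter), a step of similar size is expected here, namely a 2.8-fold higher number from compound 3 to compound 4 (0.44 log units; beyond the scatter). On that basis compound 4 is estimated at 500 nM in this assay, with a likely range from 250 nM to 1000 nM.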

Compound 4, half-maximal inhibitory concentration: 1100 nM
Estimate against measurement, compound 4: 2.2-fold (0.34 log units) below, outside the stated range (above it).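

In this assay, putting decyl in place of dec-1-en-1-yl on the core of compound 3 gave a 6.1-fold higher number from compound 3 to compound 4 (0.79 log units; beyond the scatter). The change raised the number on both cores, and the two steps cannot be told apart in size: the same change on two cores in this assay, a 2.8-fold higher number (0.45 log units; beyond the scatter) from compound 1 to compound 2 and a 6.1-fold higher number (0.79 log units; beyond the scatter) from compound 3 to compound 4, 2.2-fold (0.34 log units) apart, within the scatter of two such steps. This shows that the direction of the change carried over in these two pairs and that the larger second step should not be read as a real difference between the cores, but two pairs do not show that the change would behave the same way on any other core, nor do they explain why the saturated chain gives the higher number.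

Going by these compounds, it remains open whether the step would keep its direction and size with a shorter or longer chain or with the trans form of the double bond. On these data alone, it is also open whether it would hold on a core carrying an amine or a carboxylic acid.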